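The compounds below may be only part of what the source reports. "The series", "measured", "known", "first", "only" and "open" are said of these compounds alone.

In a functional assay on A549 cells (Homo sapiens) for antiproliferative activity, read by MTT assay, with a stated time of 72 h (a higher number here means a weaker inhibitor, a lower number a stronger inhibitor), compound 1 `Cc1ccc(-c2noc(CCCCCCC(=O)Nc3ccccc3N)n2)cc1` gives 9170 nM. Compound 2 `Nc1ccccc1NC(=O)CCCCCCc1nc(-c2ccccc2Cl)no1` reads > 100000 nM, which is a limit of the assay and not a number. Compound 3 `Nc1ccccc1NC(=O)CCCCCCc1nc(-c2ccc([N+](=O)[O-])cc2)no1` has 4-nitrophenyl in place of 2-chlorophenyl on an aromatic carbon. Going by the values given here, the only measured step bearing on this change is large: an at least 10-fold higher number from compound 1 to compound 2 (1.03 log units; beyond the scatter). That step brought in the 2-chlorophenyl that now leaves, so a sizeable move towards a lower number is expected, though a 4-nitrophenyl has not been measured here. The expected size is an at least 6.6-fold lower number from compound 2 to compound 3 (0.82 log units; beyond the scatter). Compound 3 is estimated at 15000 nM, with an expected range from 4000 nM to 60000 nM.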

Compound 3, half-maximal inhibitory concentration: > 100000 nM
Compound 3 gave a limit, no number; the forecaster's own chance of this, stated with the estimate: 15%; middle value at least 6.6-fold (0.82 log units) away from the limit.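

In this assay, putting nitro in place of the methyl of compound 1 gives an at least 10-fold higher number from compound 1 to compound 3 (1.03 log units; beyond the scatter). Two different replacements of the 4-methylphenyl on this aromatic carbon have now lost activity, so the loss is not confined to the 2-chlorophenyl of compound 2. The step between compound 2 and compound 3 cannot be read because both values are limits, not numbers: the limit of > 100000 nM in this assay, at which 2 of the 3 values shown sit.

From the compounds shown here alone, how far compound 2 and compound 3 lie past that limit remains open. So does whether a plain phenyl, a 4-methoxyphenyl or a 4-aminophenyl at this position would keep the activity of compound 1.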